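The source may report more compounds than this note shows. Statements on the series, on what has been measured and on what is new or still open speak of the compounds shown alone.

In a functional assay on A549 cells (Homo sapiens) for cytotoxicity (a lower number here means a stronger inhibitor, a higher number a weaker inhibitor), compound 1 `O=C1NC(c2ccccc2)CN1S(=O)(=O)c1ccc2c(c1)CCC2` gives 910 nM, the lowest of the two numbers recorded here. Compound 2 `Cc1ccc(S(=O)(=O)N2CC(c3ccccc3)NC2=O)cc1` is built on a different core; how the two cores differ is not broken down here. In this assay compound 2 gives 12500 nM. Compound 3 `Cc1ccc(C2CN(S(=O)(=O)c3ccc(C)cc3)C(=O)N2)cc1` is compound 2 after the change (methyl in place of hydrogen on an aromatic carbon). For compound 3 this assay reports only a limit, > 302000 nM. That limit is the limit of > 302000 nM in this assay, at which 1 of the 3 values shown sits. The step of an at least 24-fold higher number from compound 2 to compound 3 (1.38 log units; beyond the scatter) is large.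

Compound 4 `Cc1ccc(C2CN(S(=O)(=O)c3ccc4c(c3)CCC4)C(=O)N2)cc1` is compound 1 after the same change, (methyl in place of hydrogen on an aromatic carbon), made at a place described in the same words. Compound 1 starts from 910 nM, so the methyl is expected to move compound 4 to a much higher number in this assay. Among the measured compounds shown here, the expected step of a 27-fold higher number from compound 1 to compound 4 (1.44 log units; beyond the scatter) rests on an at least 24-fold higher number from compound 2 to compound 3 (1.38 log units; beyond the scatter), the only measured instance of this change. Compound 4 is thus expected to give about 25000 nM, with a range from 5000 nM to 200000 nM.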

Compound 4, half-maximal inhibitory concentration: 99200 nM
Compound 4: the middle estimate sits 4.0-fold (0.60 log units) below what was measured; measured number inside the range.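

On the core of compound 1, the change from phenyl to 4-methylphenyl weakens the compound in this assay, with a 110-fold higher number from compound 1 to compound 4 (2.04 log units; beyond the scatter), and it acts in the same direction on the core of compound 2. Set side by side, the two steps read: the same change on two cores in this assay, an at least 24-fold higher number (1.38 log units; beyond the scatter) from compound 2 to compound 3 and a 110-fold higher number (2.04 log units; beyond the scatter) from compound 1 to compound 4; the limit leaves it open whether they differ. Compound 3 stands at a limit, > 302000 nM, and the comparison therefore shows a shared direction on these two cores, but neither a shared size nor a rule for any other core.

The compounds shown leave open whether another group in the same place on the six-membered aromatic ring, such as an ethyl group, a longer chain, a methoxy group or a chlorine atom, would raise the number in this assay as methyl does. They also leave open how an amine or a carboxylic acid would behave there, and whether the loss seen with methyl would appear on a third core.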